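The source may report more compounds than this note shows. Statements on the series, on what has been measured and on what is new or still open speak of the compounds shown alone.

Notes on the series, read in a functional assay on QGY-7703 cells (Homo sapiens) for cytotoxicity, read by MTT assay, with a stated time of 24 h; on this read-out higher numbers stand for weaker inhibition and lower numbers for stronger inhibition. Compound 1 `COc1cc(/C=C2\CN(S(=O)(=O)c3ccc(F)cc3)C/C(=C\c3cc(OC)c(OC)c(OC)c3)C2=O)cc(OC)c1OC` gives 2220 nM. Compound 2 `COc1cc(/C=C2\CN(S(=O)(=O)c3ccc(F)cc3)C/C(=C\c3ccc(C#N)cc3)C2=O)cc(OC)c1OC` gives 4980 nM. Compound 3 `CC(=O)Nc1ccc(S(=O)(=O)N2C/C(=C\c3ccc(C#N)cc3)C(=O)/C(=C/c3ccccc3F)C2)cc1` gives 2050 nM. The difference between the cores of compound 2 and compound 3 is not broken down here. Compound 2 and compound 1 differ in one place, (3,4,5-trimethoxyphenyl in place of 4-cyanophenyl on a double-bonded chain carbon bound to a double-bonded ring carbon), and the step is a 2.2-fold lower number from compound 2 to compound 1 (0.35 log units; beyond the scatter). Compound 4 `COc1cc(/C=C2\CN(S(=O)(=O)c3ccc(NC(C)=O)cc3)C/C(=C\c3ccccc3F)C2=O)cc(OC)c1OC` is not yet measured in this assay; it arises from compound 3 by the same change, (3,4,5-trimethoxyphenyl in place of 4-cyanophenyl on a double-bonded chain carbon bound to a double-bonded ring carbon), the rest of the molecule being that of compound 3. Within the data shown here, the step for compound 4 is expected at a 2.1-fold lower number from compound 3 to compound 4 (0.31 log units; beyond the scatter), resting on the single earlier instance of this change, a 2.2-fold lower number from compound 2 to compound 1 (0.35 log units; beyond the scatter), with wider uncertainty because that step stands alone. Compound 4 is estimated at 1000 nM in this assay, likely between 450 nM and 2300 nM.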

Compound 4, half-maximal inhibitory concentration: 2680 nM
Estimate against measurement, compound 4: 2.7-fold (0.43 log units) below; the measured number lies above the stated range.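

In this assay the change from 4-cyanophenyl to 3,4,5-trimethoxyphenyl gives a 1.3-fold higher number from compound 3 to compound 4 (0.12 log units; within the scatter), so the gain seen on the first core does not appear on this one. The step therefore does not carry over as a fixed amount between these two cores: the same change on two cores in this assay, a 2.2-fold lower number (0.35 log units; beyond the scatter) from compound 2 to compound 1 and a 1.3-fold higher number (0.12 log units; within the scatter) from compound 3 to compound 4, 2.9-fold (0.47 log units) apart, beyond the scatter of two such steps. Among these compounds, with only one pair on each core, and the cores differing in more than one place, this does not show which part of the core governs the step, nor how it would read on any other core.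

Open, from the compounds shown here alone, is whether a third core would follow compound 1 or compound 4. Also open, going by these compounds, is how an aminomethyl or carboxylic acid group on the phenyl ring at this place would read.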